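A Sulfonamide Pair at the Limit, and a Third to Test

This account rests on a few compounds, and the source may have more. Where it says the series, first, only, none or still open, it means among the compounds named here.

Compound 1 `CCN(CC)C(=O)CN(c1cccc(N(C)C)c1C#N)S(=O)(=O)c1ccc(OC)c(OC)c1` and compound 2 `CCN(CC)C(=O)CN(c1ccc(C)cc1)S(=O)(=O)c1ccccc1F` share a sulfonamide core. In a functional assay on CHO cells for inhibition of Orexin/Hypocretin receptor type 1 (Homo sapiens), read by FLIPR and calcium flux (on this read-out higher numbers stand for weaker inhibition and lower numbers for stronger inhibition), compound 1 gives > 10000 nM, which is a limit of the assay rather than a measured number. In this assay compound 2 gives > 10000 nM, likewise a limit. Both values thus sit at the limit of > 10000 nM in this assay, at which 2 of the 2 values shown sit. Compound 3 `CCN(CC)C(=O)CN(c1cc(C(C)C)ccc1Cl)S(=O)(=O)c1ccc(OC)c(OC)c1` differs from compound 1 by 2-chloro-5-isopropylphenyl in place of 2-cyano-3-(dimethylamino)phenyl on a sulfonamide nitrogen. Within the data shown here, no measured step connects these compounds, so the expectation rests on the structures alone: a modest move toward stronger inhibition is expected, an at least 1.6-fold lower number from compound 1 to compound 3 (0.22 log units; that floor lies within the scatter), with a fair chance that only a limit is again reported. Compound 3 is therefore estimated at 6000 nM, within 1500 nM to 20000 nM.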

Compound 3, half-maximal inhibitory concentration: 888 nM
Estimate against measurement, compound 3: 6.8-fold (0.83 log units) above; measured number below the stated range.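

In this assay, placing 2-chloro-5-isopropylphenyl instead of 2-cyano-3-(dimethylamino)phenyl on the sulfonamide nitrogen gives an at least 11-fold lower number from compound 1 to compound 3 (1.05 log units; beyond the scatter). Compound 1 reports only a limit, so this step is a floor and the true change may be larger. The group at this position can therefore move the shared core off the limit, which the earlier compounds did not show: the limit of > 10000 nM in this assay, at which 2 of the 3 values shown sit.

The swap replaces the whole group at once, leaving open whether the chlorine, the isopropyl or both account for the stronger inhibition. Also open, as far as these compounds go, is whether a bromine or a tert-butyl group on that ring would do the same.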